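The compounds below may be only part of what the source reports. "The series", "measured", "known", "first", "only" and "open" are said of these compounds alone.

Measured in a functional assay on NCI-H460 cells (Homo sapiens) for cytotoxicity, read by sulforhodamine B assay, with a stated time of 48 h; on this read-out higher numbers stand for weaker inhibition of growth and lower numbers for stronger inhibition of growth:
- compound 1 (`COc1cc(C(=O)c2ccc(OC)c(O)c2OC)cc(OC)c1O`): 1970 nM
- compound 2 (`COc1cc(C(=O)c2ccc3c(c2)oc(=O)n3S(C)(=O)=O)cc(OC)c1OC`): 2640 nM

Compound 1, at 1970 nM, and compound 2, at 2640 nM, lie within the scatter of each other. Compound 3 (`COc1ccc(C(=O)c2cc(OC)c(OC)c(OC)c2)c(OC)c1O`) differs from compound 1 by methyl in place of hydrogen on an oxygen on an aromatic ring, with methyl in place of hydrogen on an oxygen on an aromatic ring, so hydroxy becomes methoxy. Among the measured compounds shown here, no measured pair shows this change, which leaves the expectation uncertain. In this assay, a clear move towards stronger inhibition of growth is expected, a 4.9-fold lower number from compound 1 to compound 3 (0.69 log units; beyond the scatter). The estimate for compound 3 is 400 nM, with an expected range of 40 nM to 3000 nM.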

Compound 3, concentration for 50% growth inhibition: 50.7 nM
Compound 3: middle estimate off by 7.9-fold (0.90 log units), on the high side; the range from low to high includes it.
By their numbers in this assay, from the lowest: compound 3; then compounds 1 and 2 (each within the scatter of the next).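

In this assay, replacing hydroxy with methoxy, a methyl in place of hydrogen on an oxygen on an aromatic ring, gives a 39-fold lower number from compound 1 to compound 3 (1.59 log units; beyond the scatter). Among the compounds shown here, this is the first single-place step, and it shows that this one methyl, on an otherwise unchanged structure, is enough to shift growth inhibition strongly. Nothing available explains the size of this step. The compounds shown leave open whether an ethoxy group or an amine at this place would keep the stronger inhibition. They also leave open whether the same change would have a comparable effect on another core.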